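Compound 3: Trifluoromethyl Takes the Place of Bromo

The source may report more compounds than this note shows. Statements on the series, on what has been measured and on what is new or still open speak of the compounds shown alone.

Going by the values given here, compound 2 `O=C(Nc1cccc(OCc2cn(-c3cccc(Br)c3)nn2)c1)Nc1ccc(Cl)c(C(F)(F)F)c1` gives 1040 nM in a functional assay on HepG2 cells (Homo sapiens) for inhibition, read by MTT assay, with a stated time of 72 h (on this read-out lower numbers stand for stronger inhibition and higher numbers for weaker inhibition), the lowest of the two numbers measured so far; its nearest neighbour is compound 1 `CCc1ccc(-n2cc(COc3cccc(NC(=O)Nc4ccc(Cl)c(C(F)(F)F)c4)c3)nn2)cc1`, which in this assay gives 1950 nM, and the two lie within the scatter of each other. Among the compounds with values here, the single measured step, a 1.9-fold lower number from compound 1 to compound 2 (0.27 log units; within the scatter), alters only the aryl group on the aromatic nitrogen. Compound 3 `O=C(Nc1cccc(OCc2cn(-c3cccc(C(F)(F)F)c3)nn2)c1)Nc1ccc(Cl)c(C(F)(F)F)c1` differs from compound 2 by trifluoromethyl in place of bromo on an aromatic carbon. This change sits at the same part of the molecule that the measured step touched, and that step stayed within the scatter, so nothing in these two measurements points to a shift beyond the scatter in this assay in either direction. The step of a 1.1-fold higher number from compound 2 to compound 3 (0.02 log units; within the scatter) is therefore expected to remain within the scatter. The estimate for compound 3 in this assay is 1100 nM, with a range from 450 nM to 2700 nM.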

Compound 3, half-maximal inhibitory concentration: 1270 nM
Estimate against measurement, compound 3: 1.2-fold (0.06 log units) below; low and high end bracket the measured number.
By their numbers in this assay, from the lowest: compounds 2, 3 and 1 (each within the scatter of the next).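

Trifluoromethyl, with four heavy atoms, can take the place of bromo, with one, on this six-membered aromatic ring of carbon only, and this assay shows no difference beyond the scatter, the step being a 1.2-fold higher number from compound 2 to compound 3 (0.09 log units; within the scatter). The comparison with the 4-ethylphenyl compound reads the same way, with a 1.5-fold lower number from compound 1 to compound 3 (0.19 log units; within the scatter), so that 4-ethylphenyl, 3-bromophenyl and 3-(trifluoromethyl)phenyl on the aromatic nitrogen now all lie within the scatter of one another, and a second replacement at this place has produced no separation among the three compounds. No measurement at hand offers an explanation for this flat result.

The compounds shown leave open whether a group of a different kind on this ring, such as an amine, a carboxylic acid or a longer chain, would move the number beyond the scatter in either direction. Also open, on these data alone, are whether trifluoromethyl would give a comparable number at another place on the ring, and whether the rest of the core, which is the same in all three compounds, would allow changes as freely.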